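Trifluoromethyl for Methyl Beyond the Assay Limit

The source may report more compounds than this note shows. Statements on the series, on what has been measured and on what is new or still open speak of the compounds shown alone.

The three measured compounds share one core and differ only in the aryl group carried on the chain bound to the ring nitrogen. Compound 1 `OC[C@H]1O[C@@H](n2cnc3c(NCc4ccc(F)cc4)ncnc32)[C@H](O)[C@@H]1O` carries a 4-fluorophenyl, and in a functional assay on HOS cells (Homo sapiens) for antiproliferative activity, with a stated time of 72 h (on this read-out lower numbers stand for stronger inhibition and higher numbers for weaker inhibition), compound 1 gives 13200 nM. Compound 2 `Cc1ccc(CNc2ncnc3c2ncn3[C@@H]2O[C@H](CO)[C@@H](O)[C@H]2O)cc1` carries a 4-methylphenyl instead. In this assay compound 2 reports only a limit, > 166000 nM, so its number is not known. Compound 3 `OC[C@H]1O[C@@H](n2cnc3c(NCc4ccccc4OC(F)F)ncnc32)[C@H](O)[C@@H]1O` carries a 2-(difluoromethoxy)phenyl. In this assay compound 3 likewise reports only a limit, > 166000 nM. Both limits coincide: the limit of > 166000 nM in this assay, at which 2 of the 3 values shown sit. The steps of an at least 12-fold higher number from compound 1 to compound 2 (1.09 log units; beyond the scatter) and an at least 12-fold higher number from compound 1 to compound 3 (1.09 log units; beyond the scatter) are thus each at least large, whereas a step that the two limits leave unreadable from compound 2 to compound 3.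

Compound 4 `OC[C@H]1O[C@@H](n2cnc3c(NCc4ccc(C(F)(F)F)cc4)ncnc32)[C@H](O)[C@@H]1O` differs from compound 2 by trifluoromethyl in place of methyl on an aromatic carbon. For the measured compounds named here, no measured step involves trifluoromethyl, and the only step that starts from compound 2 is unreadable, so nothing in these data points to a return to a readable number. The expected step is an at least 1.1-fold lower number from compound 2 to compound 4 (0.04 log units; that floor lies within the scatter). Compound 4 is therefore estimated at 150000 nM, within a range of 30000 nM to 400000 nM, and most likely reported again only as a limit.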

Compound 4, half-maximal inhibitory concentration: > 166000 nM
Compound 4 ended at the assay's limit (the forecaster's own chance of this, stated with the estimate: 60%); middle value at least 1.1-fold (0.04 log units) away from the limit.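

In this assay compound 4 reports only a limit, > 166000 nM, so trifluoromethyl on this aromatic carbon, para to a large group, yields no readable number, just as methyl did. Against fluoro at the same place the result is an at least 12-fold higher number from compound 1 to compound 4 (1.09 log units; beyond the scatter), and of the aryl groups shown only the 4-fluorophenyl of compound 1 keeps a readable number: the limit of > 166000 nM in this assay, at which 3 of the 4 values shown sit. The steps among compound 2, compound 3 and compound 4 cannot be read, so the data put methyl, trifluoromethyl and 2-(difluoromethoxy)phenyl in no order.

As far as these compounds go, whether the readable number of compound 1 is particular to fluoro remains open, and how chloro, methoxy or plain hydrogen at this place would read is unknown. From the compounds shown here alone, how far compound 2, compound 3 and compound 4 truly differ from one another also stays open.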